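Amino in place of methylsulfanyl: a single aryl swap

A few compounds are considered here, and "the series" means these few. Any claim that something is new, unique, unknown or untested is made for them only; others in the source may bear on it.

Among the compounds with values here, compound 2 `CSc1cccc(CCCCCC(=O)N2CCOC2=O)c1` gives 12800 nM in an assay on HEK293 cells for inhibition of N-acylethanolamine-hydrolyzing acid amidase (Rattus norvegicus), read by LC-MS, with a stated time of 30 min (on this read-out higher numbers stand for weaker inhibition and lower numbers for stronger inhibition), the only number in this small set. Within the data shown here, compound 1 `O=C(CCCCCc1ccc(O)c(Cl)c1)N1CCOC1=O` gives > 20000 nM in this assay and sits at the limit of > 20000 nM in this assay, at which 1 of the 2 values shown sits, which is a limit of this assay and not a number, so compound 2 stands alone as the one measured value. Compound 3 `Nc1cccc(CCCCCC(=O)N2CCOC2=O)c1` carries amino in place of methylsulfanyl on an aromatic carbon, amino in place of methylsulfanyl on an aromatic carbon. Among the measured compounds shown here, no measured step covers this change, and the expected step is a 1.2-fold higher number from compound 2 to compound 3 (0.07 log units; within the scatter), small and without a clear direction beyond the scatter. Compound 3 is estimated at 15000 nM, within 5000 nM to 40000 nM, with a fair chance of a limit.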

Compound 3, half-maximal inhibitory concentration: > 20000 nM
Compound 3 ended at the assay's limit; the forecaster's own chance of this, stated with the estimate: 40%; middle value at least 1.3-fold (0.12 log units) from the limit.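

Amino in place of methylsulfanyl on this aromatic carbon, meta to a large group, gives an at least 1.5-fold higher number from compound 2 to compound 3 (0.19 log units; that floor lies within the scatter). At this position amino therefore shows no sign of a lower number, although the floor of the step does not separate the two groups beyond the scatter. Compound 3 stands at a limit and not a number, which leaves a single number in the set: the limit of > 20000 nM in this assay, at which 2 of the 3 values shown sit.

Still open, on these data alone, is whether a methoxy group or a carboxylic acid on this aromatic carbon would give a lower number than compound 2 at 12800 nM. As far as these compounds go, the effect of a longer chain also remains open.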